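A few compounds are considered here, and "the series" means these few. Any claim that something is new, unique, unknown or untested is made for them only; others in the source may bear on it.

Measured compounds:
Compound 1 `CCc1cccc(NC(=O)c2cccc(/C=C3\CC(=O)N(Cc4ccccc4)C3=O)c2)c1`: in an ADME assay on NCM460 cells (Homo sapiens) for cytotoxicity, read by MTT assay, with a stated time of 72 h (on this read-out lower numbers stand for stronger inhibition and higher numbers for weaker inhibition), compound 1 gives > 100000 nM, which is a limit of the assay.
Compound 2 `CCc1cccc(NC(=O)c2cccc(/C=C3\CC(=O)N(c4ccccc4)C3=O)c2)c1`: in this assay compound 2 gives > 100000 nM, again a limit.
Compound 3 `O=C(Nc1ccc(Cl)cc1)c1cccc(/C=C2\CC(=O)N(c3ccccc3)C2=O)c1`: in this assay compound 3 gives > 100000 nM, also a limit.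

All three values sit at the limit of > 100000 nM in this assay, at which 3 of the 3 values shown sit. The step that the two limits leave unreadable from compound 2 to compound 1 goes with the change (benzyl in place of phenyl on an amide-type nitrogen in a ring). The step that the two limits leave unreadable from compound 2 to compound 3 goes with the change (4-chlorophenyl in place of 3-ethylphenyl on an amide-type nitrogen), which is also how the core of compound 3 differs from the core of compound 2.

Compound 4 `O=C(Nc1ccc(Cl)cc1)c1cccc(/C=C2\CC(=O)N(Cc3ccccc3)C2=O)c1` has not been measured in this assay. It differs from compound 3 by benzyl in place of phenyl on an amide-type nitrogen in a ring, the same change as that made from compound 2 to compound 1. In this assay the step of a number no higher from compound 3 to compound 4 (the limit leaves the size open) is expected, set beside a step that the two limits leave unreadable from compound 2 to compound 1, and this expectation rests on compound 1 and compound 2 both sitting at the limit of > 100000 nM in this assay, at which 3 of the 3 values shown sit. Compound 4 is therefore expected to give about 100000 nM, with a range from 30000 nM to 300000 nM, most probably reported only as a limit.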

Compound 4, half-maximal inhibitory concentration: > 100000 nM
Compound 4: only a limit was reported; the forecaster's own chance of this, stated with the estimate: 80%; the middle value lies on the limit itself.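

In this assay, for the compounds shown here, compound 4 gives > 100000 nM, which is a limit, so no step from compound 3 or compound 1 to compound 4 can be read. The compounds shown leave open whether either change alters the value at all.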